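Phenyl to 4-methylphenyl: from compound 3 to compound 4

This account rests on a few compounds, and the source may have more. Where it says the series, first, only, none or still open, it means among the compounds named here.

Compound 1 `O=C(NS(=O)(=O)c1ccccc1)n1ccc2cccnc21` is the parent of the set. In a functional assay on MCF7 cells (Homo sapiens) for antiproliferative activity, read by MTT assay, with a stated time of 24 h, tested at 10 uM (a higher number here means more inhibition at the concentration tested (going by the name of the read-out), a lower number less inhibition), compound 1 gives 19%. Compound 2 `Cc1ccc(S(=O)(=O)NC(=O)n2ccc3cccnc32)cc1` carries methyl in place of hydrogen on an aromatic carbon; in this assay compound 2 gives 20.3%, a step of a number 1.3 percentage points higher from compound 1 to compound 2 (within the scatter). Compound 3 `CN(C)c1ccnc2c1ccn2C(=O)NS(=O)(=O)c1ccccc1` carries dimethylamino in place of hydrogen on an aromatic carbon; in this assay compound 3 gives 26.9%, a step of a number 7.9 percentage points higher from compound 1 to compound 3 (within the scatter). Compound 3 therefore holds the highest of the three numbers, but its gaps to compound 2 and to compound 1 are both within the scatter, so no order among the three is established.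

Compound 4 `Cc1ccc(S(=O)(=O)NC(=O)n2ccc3c(N(C)C)ccnc32)cc1` differs from compound 3 by methyl in place of hydrogen on an aromatic carbon. For the measured compounds named here, the one measured step that bears on this change is the same change made on the parent, a number 1.3 percentage points higher from compound 1 to compound 2 (within the scatter), which stayed within the scatter. Nothing larger is expected here: the step of a number 1.1 percentage points higher from compound 3 to compound 4 (within the scatter) is expected to stay within the scatter. For compound 4 the expected value in this assay is 28%, with a range from 18% to 38%.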

Compound 4, a percentage reported as inhibition, at one concentration (the size of the read-out at that concentration, not a potency): 5.6%
Compound 4: middle estimate off by 22.4 percentage points, on the high side; the measured number lies below the stated range.
By their numbers in this assay, from the lowest: compound 4; then compounds 1, 2 and 3 (each within the scatter of the next).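

In this assay methyl on the six-membered aromatic ring of carbon only, para to a large group, does not give the same step on every core; with dimethylamino present the step is a number 21.3 percentage points lower from compound 3 to compound 4 (beyond the scatter), and the two steps of this change disagree: the same change on two cores in this assay, a number 1.3 percentage points higher (within the scatter) from compound 1 to compound 2 and a number 21.3 percentage points lower (beyond the scatter) from compound 3 to compound 4, 22.6 percentage points apart, beyond the scatter of two such steps

Read from the other side, dimethylamino in place of hydrogen gives a number 14.7 percentage points lower from compound 2 to compound 4 (beyond the scatter), so its step also depends on which aryl group is present: the same change on two cores in this assay, a number 7.9 percentage points higher (within the scatter) from compound 1 to compound 3 and a number 14.7 percentage points lower (beyond the scatter) from compound 2 to compound 4, 22.6 percentage points apart, beyond the scatter of two such steps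

In these four compounds, the two changes therefore do not sum, and only the combination in compound 4 stands apart from the others.

From the compounds shown here alone, whether the lower number is specific to methyl remains open, as a methoxy group or a carboxylic acid at the same place could show. Going by these compounds, it is also open whether an amine other than dimethylamino, such as morpholine, would pair with 4-methylphenyl in the same way.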